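This account rests on a few compounds, and the source may have more. Where it says the series, first, only, none or still open, it means among the compounds named here.

In a functional assay on PC-3 cells (Homo sapiens) for inhibition, read by sulforhodamine B assay, with a stated time of 72 h (a lower number here means a stronger inhibitor, a higher number a weaker inhibitor), compound 1 `CC1CN(C(=O)c2c(N)sc(-c3ccc(Cl)cc3)c2-c2ccc(Cl)cc2)CCN1` gives 7210 nM and compound 2 `CC(C)(C)NC(=O)c1c(N)sc(-c2ccc(Cl)cc2)c1-c1ccc(Cl)cc1` gives 15100 nM while compound 3 `Nc1sc(-c2ccc(Cl)cc2)c(-c2ccc(Cl)cc2)c1C(=O)N1CCC(=O)CC1=O` gives 9230 nM on the same read-out. These numbers place compound 3 within the scatter of both other compounds. The two steps that reach it are a 1.3-fold higher number from compound 1 to compound 3 (0.11 log units; within the scatter) and a 1.6-fold lower number from compound 2 to compound 3 (0.21 log units; within the scatter) and neither leaves the scatter. Only a 2.1-fold higher number from compound 1 to compound 2 (0.32 log units; beyond the scatter) goes beyond it, and then only modestly.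

The next structure is compound 4 `Nc1sc(-c2ccc(Cl)cc2)c(-c2ccc(Cl)cc2)c1C(=O)NCc1ccccc1` and the change that leads to it is benzylamino in place of 2,4-dioxopiperidin-1-yl on a carbonyl carbon with benzylamino in place of 2,4-dioxopiperidin-1-yl on a carbonyl carbon. Among the compounds with values here, no measured compound carries benzylamino, so the evidence is indirect. It rests on the three exchanges already seen on that same carbonyl carbon, where quite different groups, including (tert-butyl)amino, moved the number little. The largest of these was the modest step of a 2.1-fold higher number from compound 1 to compound 2 (0.32 log units; beyond the scatter) and so no step beyond the scatter is expected in this assay for this new exchange, and no direction is favoured with any confidence. The expected change is a 1.0-fold higher number from compound 3 to compound 4 (0.01 log units; within the scatter) and it remains an estimate. For compound 4 the estimated value is 9500 nM with an expected range from 4500 nM to 20000 nM on this evidence.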

Compound 4, half-maximal inhibitory concentration: 31800 nM
The estimate for compound 4 lay 3.3-fold (0.52 log units) below the measured number; measured number outside the range, above it.
By their numbers in this assay, from the lowest: compounds 1, 3 and 2 (each within the scatter of the next, the first and the last beyond it); then compound 4.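

In this assay the position on the carbonyl carbon proves less indifferent than the first three compounds suggested: benzylamino in place of 2,4-dioxopiperidin-1-yl gives a 3.4-fold higher number from compound 3 to compound 4 (0.54 log units; beyond the scatter) and benzylamino in place of 3-methylpiperazin-1-yl gives a 4.4-fold higher number from compound 1 to compound 4 (0.64 log units; beyond the scatter), so this exchange can weaken inhibition, if only modestly. The change need not remove a ring from the carbonyl carbon or alter the amide-type nitrogen's hydrogen to have this result, since benzyl in place of tert-butyl on that nitrogen still gives a 2.1-fold higher number from compound 2 to compound 4 (0.32 log units; beyond the scatter) and leaves compound 4 as the weakest inhibitor of the four. No data shown bear on why benzylamino behaves this way.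

What the compounds leave open is whether the loss follows the benzene ring itself or the carbon linking it to the nitrogen, which anilino, 2-phenylethylamino or cyclohexylmethylamino on the same carbonyl carbon could begin to separate. On these data alone, it also remains open whether a hydroxyl or an amine on the benzyl ring would change the number at this position.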